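Replacing One Chlorinated Phenyl Ring with Another

A few compounds are considered here, and "the series" means these few. Any claim that something is new, unique, unknown or untested is made for them only; others in the source may bear on it.

Measured in a functional assay on BJAB cells (Homo sapiens) for antiproliferative activity, with a stated time of 4 days; a higher number here means that more compound is needed for the effect, a lower number that less compound is needed:
Compound 1 `Cc1nn(-c2nc(-c3ccc(Cl)c(Cl)c3)c(SC(C)C)s2)c(C(=O)O)c1Cc1ccccc1[N+](=O)[O-]` gives 20000 nM.
Compound 2 `Cc1nn(-c2nc(-c3ccc(Cl)c(Cl)c3)c(SC(C)C)s2)c(C(=O)O)c1-c1cncnc1` gives 22000 nM.
Compound 3 `Cc1cc(Cl)cc(-c2c(C)nn(-c3nc(-c4ccc(Cl)c(Cl)c4)c(SC(C)C)s3)c2C(=O)O)c1` gives 663 nM.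

Compound 3 stands lowest of the three numbers: a 30-fold lower number from compound 1 to compound 3 (1.48 log units; beyond the scatter) and a 33-fold lower number from compound 2 to compound 3 (1.52 log units; beyond the scatter), while a 1.1-fold higher number from compound 1 to compound 2 (0.04 log units; within the scatter). Compound 4 `Cc1nn(-c2nc(-c3ccc(Cl)c(Cl)c3)c(SC(C)C)s2)c(C(=O)O)c1-c1ccc(Cl)cc1` carries the change (4-chlorophenyl in place of 3-chloro-5-methylphenyl on an aromatic carbon). Both the group that leaves and the group that enters are a six-membered aromatic ring of carbon only bearing one chlorine; the leaving group also carries a methyl. For the measured compounds named here, no measured step swaps one such ring for another, so the large steps to compound 3 bear on it only indirectly, in that a directly attached carbon ring sits far below the other two groups. A modest rise is therefore expected, a 2.3-fold higher number from compound 3 to compound 4 (0.35 log units; beyond the scatter). Compound 4 is estimated at 1500 nM, within 400 nM to 6000 nM.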

Compound 4, half-maximal effective concentration: 2500 nM
Estimate against measurement, compound 4: 1.7-fold (0.22 log units) below, and the stated range covers the measured number.
By their numbers in this assay, from the lowest: compound 3; then compound 4; then compounds 1 and 2 (each within the scatter of the next).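

Exchanging one chlorinated phenyl ring for another at this position still shifts the number, so the groups on the ring matter and not only the ring itself (a 3.8-fold higher number from compound 3 to compound 4 (0.58 log units; beyond the scatter)). Compound 4 nevertheless stays well under the two compounds without a directly attached carbon ring (an 8.8-fold lower number from compound 2 to compound 4 (0.94 log units; beyond the scatter); an 8.0-fold lower number from compound 1 to compound 4 (0.90 log units; beyond the scatter)). No measurement here accounts for these differences. On these data alone, compound 4 loses the methyl and moves the chlorine in one change, so the share of each stays open. Also open, as far as these compounds go, is how a phenyl ring carrying an amine or a methoxy group would behave here.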